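The source may report more compounds than this note shows. Statements on the series, on what has been measured and on what is new or still open speak of the compounds shown alone.

Measured compounds in a physicochemical assay for lipophilicity; on this read-out higher numbers stand for higher lipophilicity and lower numbers for lower lipophilicity: compound 1 `CCOC(=O)C1=C(C)NC(=S)NC1c1cn(C(=O)CNc2ccccc2Cl)c2ccccc12` gives 3.44; compound 2 `CCOC(=O)C1=C(C)NC(=S)NC1c1cn(C(=O)CNc2ccc([N+](=O)[O-])c(Cl)c2)c2ccccc12` gives 3.4; compound 3 `CCOC(=O)C1=C(C)NC(=S)NC1c1cn(C(=O)CNc2ccc([N+](=O)[O-])cc2C)c2ccccc12` gives 3.34.

Compound 3 holds the lowest of the three numbers, but its nearest neighbour, compound 2, is within the scatter, as is compound 1, so no order among the three can be claimed in this assay.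

Compound 4 `CCOC(=O)C1=C(C)NC(=S)NC1c1cn(C(=O)CNc2ccccc2[N+](=O)[O-])c2ccccc12` is not yet measured. The change from compound 3 is 2-nitrophenyl in place of 2-methyl-4-nitrophenyl on an amine nitrogen.

The measured steps that bear on it all swap one substituted phenyl ring for another on the same amine nitrogen: a number 0.04 log units lower from compound 1 to compound 2 (within the scatter), a number 0.10 log units lower from compound 1 to compound 3 (within the scatter) and a number 0.06 log units lower from compound 2 to compound 3 (within the scatter). Each stayed within the scatter. The step to compound 4 removes a methyl as well as moving the nitro group, so a small downward movement in this assay is expected for compound 4, though it may well stay within the scatter.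

Compound 4 is expected to give 3.15 in this assay, between 2.75 and 3.55, a step of a number 0.19 log units lower from compound 3 to compound 4 (within the scatter).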

Compound 4, partition coefficient: 2.88
Compound 4: the middle estimate sits 0.27 log units above what was measured, within the range that was stated.
By their numbers in this assay, from the lowest: compound 4; then compounds 3, 2 and 1 (each within the scatter of the next).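

In this assay, among these compounds, changing the aryl group on the amine nitrogen now gives steps beyond the scatter, which no earlier pair showed: a number 0.46 log units lower from compound 3 to compound 4 (beyond the scatter), a number 0.52 log units lower from compound 2 to compound 4 (beyond the scatter) and a number 0.56 log units lower from compound 1 to compound 4 (beyond the scatter). A nitro group alone does not go with a lower number, since compound 2 and compound 3 both carry one and stay within the scatter of compound 1, so the shift is tied so far to the 2-nitrophenyl group of compound 4. No measurement shown accounts for this shift.

Going by these compounds, with a single 2-nitrophenyl example, it remains open whether the shift belongs to the nitro group itself or to that ring as a whole. An unsubstituted phenyl on the same amine nitrogen, or a nitrile or carboxylic acid in place of the nitro of compound 4, would help separate the two.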